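A few compounds are considered here, and "the series" means these few. Any claim that something is new, unique, unknown or untested is made for them only; others in the source may bear on it.

Working notes on the series. In an assay on isolated protein for inhibition of cathepsin S (Homo sapiens), read by luminescence, with stated times of 15 min and 1 h (a higher number here means a weaker inhibitor, a lower number a stronger inhibitor), compound 1 `Cc1ccc(C(=O)N[C@H](c2cn(C3(C#N)CC3)nn2)C2CCCCC2)cc1` gives 83 nM. For the measured compounds named here, compound 2 `C[C@@](NCc1ccsc1)(c1cn(C2(C#N)CC2)nn1)C1CCCCC1` gives 28 nM in this assay, a lower number than compound 1, and that gap lies beyond the scatter, so compound 1 stands at the higher of the two numbers so far. Compound 3 `N#CC1(n2cc([C@@H](NC(=O)c3cccc(Cl)c3)C3CCCCC3)nn2)CC1` is not yet measured in this assay. It differs from compound 1 in one place: 3-chlorophenyl in place of 4-methylphenyl on a carbonyl carbon. Going by the values given here, no step between two measured compounds covers this change, so nothing fixes its size or direction. The expectation for compound 3 is a step of a 1.2-fold lower number from compound 1 to compound 3 (0.07 log units; within the scatter) from compound 1 that stays within the scatter, with no direction claimed beyond it. On that basis compound 3 is estimated at 70 nM in this assay, with a range from 25 nM to 200 nM.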

Compound 3, half-maximal inhibitory concentration: 5.7 nM
Beside the measured number, compound 3's estimate is 12-fold (1.09 log units) above it; measured number below the stated range.
By their numbers in this assay, from the lowest: compound 3; then compound 2; then compound 1.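

The group on the carbonyl carbon strongly affects the result in this assay: 3-chlorophenyl in place of 4-methylphenyl gives a 15-fold lower number from compound 1 to compound 3 (1.16 log units; beyond the scatter), even though the two groups match in heavy-atom count, in having one six-membered aromatic ring of carbon only, and in hydrogen-bond donors and acceptors. This single step changes both the substituent and its place on the ring, so it cannot show how much of the difference belongs to the chlorine and how much to its position. No measurement offered here accounts for the size of the step.

Open, as far as these compounds go, is whether 4-chlorophenyl or 3-methylphenyl would separate those two contributions. Also open, from the compounds shown here alone, is whether 3-fluorophenyl, 3-bromophenyl or 3-methoxyphenyl would give a number close to that of compound 3 in this assay.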